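This account rests on a few compounds, and the source may have more. Where it says the series, first, only, none or still open, it means among the compounds named here.

Of the compounds shown here, three built on one shared core have been measured in a functional assay on U-251 cells (Homo sapiens) for inhibition, read by sulforhodamine B assay, with a stated time of 48 h; a higher number here means that more compound is tolerated, a lower number that less compound is tolerated. Compound 1 `COc1cc(-c2cc(/C=C/C(=O)c3ccc(N)cc3)[nH]n2)cc(OC)c1OC` gives 5390 nM in this assay. Compound 2 `COc1ccc(-c2cc(/C=C/C(=O)c3ccc(OC)c(OC)c3)[nH]n2)cc1` gives 4970 nM. Compound 3 `COc1ccc(-c2cc(/C=C/C(=O)c3ccc(N)cc3)[nH]n2)cc1OC` gives 7690 nM, the highest of the three numbers, yet its gaps to compound 1 and to compound 2 both lie within the usual scatter, so no real ordering among the three can be claimed. Compound 4 `COc1ccc(-c2cc(/C=C/C(=O)c3ccc(N)cc3)[nH]n2)cc1` has not yet been measured. The change from compound 3 to compound 4 is hydrogen in place of methoxy on an aromatic carbon. For the measured compounds named here, one measured step bears on it: the same kind of change, hydrogen in place of methoxy on an aromatic carbon, was seen a 1.4-fold higher number from compound 1 to compound 3 (0.15 log units; within the scatter), a shift too small to count. Going by the values given here, with only that step to go on, the expectation is that the number in this assay stays close to that of compound 3. The resulting step is estimated as a 1.0-fold lower number from compound 3 to compound 4 (0.01 log units; within the scatter). Compound 4 is therefore expected to give 7500 nM in this assay, with a likely range from 3800 nM to 15000 nM.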

Compound 4, concentration lethal to 50% of the cells: 5300 nM
For compound 4 the middle estimate is 1.4-fold (0.15 log units) above the measured one; the measured number falls inside the stated range.
By their numbers in this assay, from the lowest: compounds 2, 4, 1 and 3 (each within the scatter of the next).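

In this assay, replacing methoxy with hydrogen on this aromatic carbon, ortho to a methoxy group and meta to a large group, gives a 1.5-fold lower number from compound 3 to compound 4 (0.16 log units; within the scatter) and so produces no readable change. The same kind of swap on this ring also gave a 1.4-fold higher number from compound 1 to compound 3 (0.15 log units; within the scatter) and, although the two steps appear to point in opposite directions, both lie within the scatter, so neither direction carries meaning and the swap has shown no real effect in either case. Nothing measured here offers an explanation for these small steps.

Going by these compounds, whether a different group on this carbon, such as a hydroxyl, a chlorine atom or a longer ethoxy chain, would move the number beyond the scatter remains open. Also open, on these data alone, is what would happen if the last methoxy on the ring of compound 4 gave way to hydrogen.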